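Side-chain swap from compound 3 to compound 4

The source may hold more compounds than are shown below. What is called first, only, known or untested is meant among the compounds shown, and "the series" means these compounds.

In a functional assay on HeLa cells (Homo sapiens) for cytotoxicity, read by MTT assay (on this read-out lower numbers stand for stronger inhibition and higher numbers for weaker inhibition), compound 1 (`COC(C)CO[C@H](CC=C(C)C)C1=CC(=O)c2c(O)ccc(O)c2C1=O`) gives 53400 nM, compound 2 (`CC(C)=CC[C@@H](OCC(C)O)C1=CC(=O)c2c(O)ccc(O)c2C1=O`) gives 24700 nM, and compound 3 (`CCC(CO[C@H](CC=C(C)C)C1=CC(=O)c2c(O)ccc(O)c2C1=O)OC(C)=O`) gives 44000 nM. Compound 3 therefore stands within the scatter of both other compounds: a 1.2-fold lower number from compound 1 to compound 3 (0.08 log units; within the scatter) and a 1.8-fold higher number from compound 2 to compound 3 (0.25 log units; within the scatter). For the measured compounds named here, the only step beyond the scatter is a modest one, a 2.2-fold lower number from compound 1 to compound 2 (0.33 log units; beyond the scatter).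

Compound 4 (`CC(C)=CC[C@@H](OC(=O)C1CCOC1)C1=CC(=O)c2c(O)ccc(O)c2C1=O`) keeps the shared core, and (oxolan-3-yl)carbonyl takes the place of 2-acetoxybutyl on an oxygen on a saturated carbon: (oxolan-3-yl)carbonyl in place of 2-acetoxybutyl on an oxygen on a saturated carbon. The measured steps bear on this only indirectly. Each alters a group within the chain on that oxygen, and none replaces the chain as a whole, so the data hold no direct measure of this change. Those smaller changes moved the number little, the largest being a 2.2-fold lower number from compound 1 to compound 2 (0.33 log units; beyond the scatter).

On that basis, no shift beyond the scatter is expected in this assay, with only a slight lean towards a lower number. The expected step is a 1.5-fold lower number from compound 3 to compound 4 (0.17 log units; within the scatter). For compound 4 the estimated value is 30000 nM, with an expected range of 10000 nM to 70000 nM, kept wide since the whole chain is replaced.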

Compound 4, half-maximal inhibitory concentration: 73500 nM
Compound 4: the middle estimate sits 2.5-fold (0.39 log units) below what was measured, and the stated range ends below it.
By their numbers in this assay, from the lowest: compounds 2, 3, 1 and 4 (each within the scatter of the next, the first and the last beyond it).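

Replacing the whole chain on the oxygen, rather than a group within it, does not separate (oxolan-3-yl)carbonyl from the two capped open chains in this assay: the shift is a 1.7-fold higher number from compound 3 to compound 4 (0.22 log units; within the scatter) against 2-acetoxybutyl and a 1.4-fold higher number from compound 1 to compound 4 (0.14 log units; within the scatter) against 2-methoxypropyl. The position therefore accepts a five-membered non-aromatic ring and a carbonyl in this chain with no shift beyond the scatter from either of these compounds. Only the comparison with the 2-hydroxypropyl chain of compound 2 passes the scatter, and modestly so, with a 3.0-fold higher number from compound 2 to compound 4 (0.47 log units; beyond the scatter) as the widest gap in the set, although no information is available on what lies behind this gap.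

On these data alone, with the ring and the carbonyl entering together, their separate contributions remain open, and an open-chain butanoyl or a simple acetyl on the same oxygen would be needed to tell them apart. Also open, as far as these compounds go, is how this position responds to an amine or a carboxylic acid at the end of the chain, or to a longer chain ending in a hydroxyl.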